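Triazolobenzophenone series: cyclopropyl replacing methyl on the triazole carbon

The source may report more compounds than this note shows. Statements on the series, on what has been measured and on what is new or still open speak of the compounds shown alone.

Measured so far in a functional assay on the whole organism (strain CF-1) for inhibition, with Mus musculus as the target; on this read-out lower numbers stand for an effect already at smaller amounts and higher numbers for an effect only at larger amounts of compound:
- compound 1, `Cc1nnc(CN(C)C)n1-c1ccc(Cl)cc1C(=O)c1ccccc1`: 0.5 mg/kg
- compound 2, `CN(C)Cc1nnc(-c2ccncc2)n1-c1ccc(Cl)cc1C(=O)c1ccccc1Cl`: 11 mg/kg
- compound 3, `Cc1nnc(CN(C)C)n1-c1ccc(Cl)cc1C(=O)c1ccccc1Cl`: 0.14 mg/kg

Compound 3 gives the lowest number of the three. Its nearest neighbour is compound 1, and the step of a 3.6-fold lower number from compound 1 to compound 3 (0.55 log units; beyond the scatter) came from the chloro entering in place of hydrogen on the second aromatic ring. Its furthest neighbour is compound 2, and the step of a 79-fold lower number from compound 2 to compound 3 (1.90 log units; beyond the scatter) came from methyl entering in place of pyridin-4-yl on the triazole carbon.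

Compound 4, `CN(C)Cc1nnc(C2CC2)n1-c1ccc(Cl)cc1C(=O)c1ccccc1Cl`, is not yet measured. It differs from compound 3 by cyclopropyl in place of methyl on an aromatic carbon. Going by the values given here, the only measured step at this position is the one from compound 2 to compound 3, where a large change of the group at this carbon moved this assay a long way. Cyclopropyl is a smaller change than pyridin-4-yl, so a smaller shift is expected, in the same direction of a higher number, but with wide uncertainty since no second example at this carbon exists.

For compound 4 the expected step is a 2.9-fold higher number from compound 3 to compound 4 (0.46 log units; beyond the scatter), giving an estimate of 0.4 mg/kg with a range from 0.12 mg/kg to 1.5 mg/kg in this assay.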

Compound 4, dose for half-maximal effect: 0.6 mg/kg
Compound 4: middle estimate off by 1.5-fold (0.18 log units), on the low side; the range from low to high includes it.
By their numbers in this assay, from the lowest: compound 3; then compounds 1 and 4 (each within the scatter of the next); then compound 2.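

In this assay, the aromatic carbon between two ring nitrogen atoms now has a third group to compare, and even the small non-aromatic ring does not match methyl: a 4.3-fold higher number from compound 3 to compound 4 (0.63 log units; beyond the scatter). Against the other measured group at this carbon, cyclopropyl still gives the better result, with an 18-fold lower number from compound 2 to compound 4 (1.26 log units; beyond the scatter), so the three groups run from the lowest number to the highest as methyl, cyclopropyl, pyridin-4-yl, and the step from pyridin-4-yl is the larger of the two new steps. No evidence on the cause of these shifts is at hand.

Three groups at one carbon cannot show whether the rise follows the number of heavy atoms, the presence of a ring, or the kind of ring; ethyl and isopropyl would set open chains beside cyclopropyl, while phenyl would set a carbon-only aromatic ring beside pyridin-4-yl. It also remains open whether methyl is the best group at this carbon, since hydrogen is not among the compounds shown, and whether the cyclopropyl step holds when hydrogen replaces the chloro on the second aromatic ring.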